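The compounds below may be only part of what the source reports. "The series", "measured", "known", "first", "only" and "open" are said of these compounds alone.

In an ADME assay on MRC5 cells (Homo sapiens) for inhibition, with a stated time of 72 h (a higher number here means that more compound is needed for the effect, a lower number that less compound is needed), compound 2 `COc1cccc(OC)c1C(=O)Nc1c[nH]nc1C(=O)NCc1ccccn1` gives only the limit of > 50000 nM, so no number is known for it. Compound 1 `CO[C@H]1CC[C@H](NC(=O)c2n[nH]cc2NC(=O)c2ccc(N3CCCC3)cc2)CC1` likewise gives only the limit of > 50000 nM. Among the compounds with values here, both sit at the limit of > 50000 nM in this assay, at which 2 of the 2 values shown sit, and no step between measured compounds can be read. Compound 3 `COc1cccc(OC)c1C(=O)Nc1c[nH]nc1C(=O)NCCCN(C)C` differs from compound 2 in one place: 2-(dimethylamino)ethyl in place of pyridin-2-yl on a saturated chain carbon bound to an amide-type nitrogen. With both measured values at the limit, the step of a number no higher from compound 2 to compound 3 (the limit leaves the size open) is expected to show no change beyond the scatter. Compound 3 is thus expected to give 50000 nM, in a range of 20000 nM to 200000 nM, most probably again as a limit.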

Compound 3, half-maximal effective concentration: > 50000 nM
Compound 3: only a limit was reported (the forecaster's own chance of this, stated with the estimate: 85%); the middle value sits exactly at the limit.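

Within the data shown here, compound 2 and compound 3 both give only a limit in this assay, so no step between them can be read. The compounds shown leave open how much of each is needed for the effect, and whether 2-(dimethylamino)ethyl in place of pyridin-2-yl changes that amount.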